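This account rests on a few compounds, and the source may have more. Where it says the series, first, only, none or still open, it means among the compounds named here.

Measured so far in a physicochemical assay for solubility, in phosphate buffer, with a stated time of 18 h (a lower number here means a less soluble compound, a higher number a more soluble compound), are these compounds:
- compound 1 `CSc1nc(C(C)(C)C)nc2nc(N)c(C#N)c(N)c12` with 14000 nM
- compound 2 `CC(C)(C)c1nc(CCCCCC#N)c2c(N)c(C#N)c(N)nc2n1` with 6000 nM
- compound 3 `CC(C)(C)c1nc(-c2ccc(C(=O)O)s2)c2c(N)c(C#N)c(N)nc2n1` with > 1000000 nM as a limit, not a number

Compound 3 stands at the limit of > 1000000 nM in this assay, at which 1 of the 3 values shown sits, and has no number of its own. Compound 4 `CC(C)(C)c1nc(-c2nc(CO)cs2)c2c(N)c(C#N)c(N)nc2n1` has not been measured yet. The change from compound 3 to compound 4 is 4-(hydroxymethyl)-1,3-thiazol-2-yl in place of 5-carboxythiophen-2-yl on an aromatic carbon. Two large measured steps bear on this, an at least 71-fold higher number from compound 1 to compound 3 (1.85 log units; beyond the scatter) and an at least 160-fold higher number from compound 2 to compound 3 (2.22 log units; beyond the scatter), and both bring that 5-carboxythiophen-2-yl group in. Compound 4 gives the group up, so a large step to a lower number in this assay is expected, back towards compound 1 and compound 2. The estimated step is an at least 50-fold lower number from compound 3 to compound 4 (1.69 log units; beyond the scatter) in size. Compound 4 is estimated at 20000 nM with 5000 nM to 100000 nM as its range.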

Compound 4, solubility: < 1000 nM
Compound 4 was reported as a limit; the forecaster's own chance of this, stated with the estimate: 5%; middle value at least 20-fold (1.30 log units) away from the limit.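

In this assay, this position also tolerates a group that gives a lower number than the earlier methylsulfanyl and 5-cyanopentyl groups, with an at least 14-fold lower number from compound 1 to compound 4 (1.14 log units; beyond the scatter) and an at least 6.0-fold lower number from compound 2 to compound 4 (0.77 log units; beyond the scatter). A five-membered aromatic ring here is now found at both ends of the series, with an at least 1000-fold lower number from compound 3 to compound 4 (3.00 log units; beyond the scatter). Compound 4 carries a limit, not a number: the limit of < 1000 nM in this assay, at which 1 of the 4 values shown sits.

On these data alone, the true size of these steps stays open. Also open, as far as these compounds go, is whether the ring or its substituent carries the difference, which a thiophen-2-yl group carrying hydroxymethyl, or a 1,3-thiazol-2-yl group carrying a carboxylic acid, would separate.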